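One Amine Swap Carried Over to a Second Core

The source may hold more compounds than are shown below. What is called first, only, known or untested is meant among the compounds shown, and "the series" means these compounds.

compound 1 `CCCCN(CCCC)Cc1cn(CC(O)COCc2ccccc2)nn1`: 6%
compound 2 `CN(Cc1cn(C2CCCCC2OC(=O)COc2ccccc2)nn1)CC1CCCCC1`: 37%
compound 3 `CCCCN(CCCC)Cc1cn(C2CCCCC2OC(=O)COc2ccccc2)nn1`: 26%

Of the compounds shown here, three have been measured in an assay on nucleic acid for inhibition of Nucleic Acid, read by fluorescence, tested at 100 uM; on this read-out lower numbers stand for less inhibition and higher numbers for more inhibition at the one concentration tested (going by the name of the read-out). Compound 3 gives 26% and compound 2 gives 37%; one change separates them, ((cyclohexylmethyl)(methyl)amino in place of dibutylamino on a saturated chain carbon bound to an aromatic carbon), and it made a step of a number 11 percentage points higher from compound 3 to compound 2 (beyond the scatter). Compound 1 gives 6%, the lowest of the three; the difference between its core and that of compound 3 is not broken down here. Compound 4 `CN(Cc1cn(CC(O)COCc2ccccc2)nn1)CC1CCCCC1` has not yet been measured. It carries the same change on the core of compound 1: (cyclohexylmethyl)(methyl)amino in place of dibutylamino on a saturated chain carbon bound to an aromatic carbon. Because the earlier step was a number 11 percentage points higher from compound 3 to compound 2 (beyond the scatter), compound 4 is expected to show a number 11 percentage points higher from compound 1 to compound 4 (beyond the scatter), an expectation resting on that single pair. In this assay compound 4 is therefore estimated at about 17%, most likely between 5% and 30%.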

Compound 4, a percentage reported as inhibition, at one concentration (the size of the read-out at that concentration, not a potency): 6%
Beside the measured number, compound 4's estimate is 11 percentage points above it; measured number inside the range.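

In this assay, (cyclohexylmethyl)(methyl)amino in place of dibutylamino made no change at the digits printed from compound 1 to compound 4 (within the scatter). This shows no measurable gain from the change on the core of compound 1, but with one pair on each core it shows neither that the change carries over nor that it fails to. The two steps cannot be told apart, so the data do not show that the core alters the effect of the change: the same change on two cores in this assay, a number 11 percentage points higher (beyond the scatter) from compound 3 to compound 2 and no change at the digits printed (within the scatter) from compound 1 to compound 4, 11 percentage points apart, within the scatter of two such steps

The compounds shown leave open how a morpholine or a piperazine would behave on a saturated chain carbon bound to an aromatic carbon. They also leave open whether either core would respond to such amines in the same way.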